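Compound 1 and its missing side group

The source may hold more compounds than are shown below. What is called first, only, known or untested is meant among the compounds shown, and "the series" means these compounds.

Measured in a functional assay on MCF7 cells (Homo sapiens) for inhibition, read by fluorescence, with a stated time of 72 h; on this read-out lower numbers stand for stronger inhibition and higher numbers for weaker inhibition:
- compound 1 `CC(C)n1cnc2c(NC(=N)N)nc(N)nc21`: 97200 nM
- compound 2 `N=C(N)Nc1nc(N)nc2c1ncn2CCO`: > 100000 nM (a limit)
- compound 3 `N=C(N)Nc1nc(N)nc2c1ncn2CCN`: > 100000 nM (a limit)

For the measured compounds named here, compound 1 has the only actual number, set against (the limit of > 100000 nM in this assay, at which 2 of the 3 values shown sit). Compound 4 `CC(C)n1cnc2c(N)nc(N)nc21` has not been measured yet. Its change from compound 1 is a hydrogen atom in place of a group of 3 heavy atoms (1 carbon, 2 nitrogen; no ring), on a nitrogen on an aromatic ring, on a nitrogen on an aromatic ring.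

Going by the values given here, no measured step touches that place. Two steps swap the isopropyl instead: an at least 1.0-fold higher number from compound 1 to compound 2 (0.01 log units; that floor lies within the scatter) and an at least 1.0-fold higher number from compound 1 to compound 3 (0.01 log units; that floor lies within the scatter), and both floors lie within the scatter. The third, a step that the two limits leave unreadable from compound 2 to compound 3, cannot be read. With only compound 1 at 97200 nM as a guide, no size can be carried over.

In this assay the expected result is a 1.4-fold lower number from compound 1 to compound 4 (0.14 log units; within the scatter), with no step beyond the scatter and no direction predicted. The estimate for compound 4 is 70000 nM, with an expected range of 20000 nM to 100000 nM.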

Compound 4, half-maximal inhibitory concentration: > 100000 nM
Compound 4 gave a limit, no number (the forecaster's own chance of this, stated with the estimate: 45%); middle value at least 1.4-fold (0.15 log units) away from the limit.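

In this assay, a hydrogen atom in place of the group of 3 heavy atoms on the nitrogen gives an at least 1.0-fold higher number from compound 1 to compound 4 (0.01 log units; that floor lies within the scatter). For the compounds shown here, this is the first look at this position, and compound 4 carries a limit, not a number, so the step has only a floor and its true size stays unknown. Removing the group reveals no stronger inhibition, and the compounds mostly sit at one value: the limit of > 100000 nM in this assay, at which 3 of the 4 values shown sit.

On these data alone, how much the group adds to inhibition remains open. So does whether an acetyl group or a longer chain ending in an amine on that nitrogen would give a readable number.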